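Working notes: from compound 2 to compound 4

The compounds below may be only part of what the source reports. "The series", "measured", "known", "first", "only" and "open" are said of these compounds alone.

Measured so far:
- compound 1 `O=C(Nc1cccc(-n2cc(-c3ccncc3)c(-c3ccc(Cl)c(O)c3)n2)c1)Nc1ccc(Cl)c(Cl)c1`: > 32500 nM in a functional assay on SK-MEL-2 cells (Homo sapiens) for inhibition, read by sulforhodamine B assay, with a stated time of 48 h; a higher number here means that more compound is tolerated, a lower number that less compound is tolerated
- compound 2 `COc1cc(-c2nn(-c3cccc(NC(=O)c4ccc(Cl)c(C(F)(F)F)c4)c3)cc2-c2ccncc2)ccc1Cl`: > 32500 nM in this assay
- compound 3 `O=C(Nc1cccc(-n2cc(-c3ccncc3)c(-c3ccc(Cl)c(O)c3)n2)c1)Nc1cc(C(F)(F)F)cc(C(F)(F)F)c1`: 14100 nM in this assay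

For compound 2 the value in this assay is a limit of the assay and not a number. It is the limit of > 32500 nM in this assay, at which 2 of the 3 values shown sit. Within the data shown here, the only value given as a number in the set is that of compound 3, 14100 nM. Among the measured compounds shown here, no pair of measured compounds differs in one place, so no measured step is available.

Compound 4 `COc1cc(-c2nn(-c3cccc(NC(=O)Nc4cccc(C(F)(F)F)c4)c3)cc2-c2ccncc2)ccc1Cl` differs from compound 2 as follows: (3-(trifluoromethyl)phenyl)amino in place of 4-chloro-3-(trifluoromethyl)phenyl on a carbonyl carbon. Since compound 2 reports only a limit, the change from compound 2 to compound 4 can be expected to be within the scatter or to move toward a lower number, and the expected step is an at least 1.3-fold lower number from compound 2 to compound 4 (0.11 log units; that floor lies within the scatter). The expectation for compound 4 leans on compound 3 and its value of 14100 nM. Compound 1 stays at a limit, > 32500 nM. Compound 4 is estimated at 25000 nM, in the range 9000 nM to 60000 nM.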

Compound 4, concentration lethal to 50% of the cells: 3960 nM
Compound 4: the middle estimate sits 6.3-fold (0.80 log units) above what was measured; measured number outside the range, below it.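

Placing (3-(trifluoromethyl)phenyl)amino in place of 4-chloro-3-(trifluoromethyl)phenyl on a carbonyl carbon, with an amide-type nitrogen as its other neighbour, gives in this assay an at least 8.2-fold lower number from compound 2 to compound 4 (0.91 log units; beyond the scatter). Compound 2 stands at a limit of the assay and not at a number, so this step gives only the smallest size of the change: the limit of > 32500 nM in this assay, at which 2 of the 4 values shown sit. Among these compounds, this is the first measured step, and it shows that the group on this carbonyl carbon can move the number beyond the scatter.

The change adds an amino nitrogen and removes the ring chlorine together, and the compounds shown do not separate these two parts. Also open, on these data alone, is how (4-chloro-3-(trifluoromethyl)phenyl)amino, or a saturated amine such as piperidine, would read on the same carbonyl carbon.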